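Cyclopentyl for cyclopropyl: how much clearance returns?

A few compounds are considered here, and "the series" means these few. Any claim that something is new, unique, unknown or untested is made for them only; others in the source may bear on it.

Three compounds sharing one core have a measured clearance so far. In an in vitro ADME assay on microsomes from liver (Mus musculus) for pharmacokinetics, read by LC-MS, with a stated time of 10 min, tested at 1 uM (a lower number here means slower removal, a higher number faster removal of the compound), compound 1 (`CN1C[C@H](C(=O)Nc2ccc(C3CC3)cc2)[C@@H](c2ccc(/C=C/C(=O)Nc3ccccc3N)cc2)C1`) gives 60 mL/min/kg and compound 2 (`COc1cccc(NC(=O)[C@H]2CN(C)C[C@@H]2c2ccc(/C=C/C(=O)Nc3ccccc3N)cc2)c1`) gives 65 mL/min/kg as its number. The gap between them is a 1.1-fold higher number from compound 1 to compound 2 (0.03 log units; within the scatter) and nothing more. Compound 3 (`CN1C[C@H](C(=O)NC2CC2)[C@@H](c2ccc(/C=C/C(=O)Nc3ccccc3N)cc2)C1`) stands lowest of the three with 7 mL/min/kg as its number, so it is removed the most slowly.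

Compound 4 (`CN1C[C@H](C(=O)NC2CCCC2)[C@@H](c2ccc(/C=C/C(=O)Nc3ccccc3N)cc2)C1`) has not been measured yet. It has cyclopentyl in place of cyclopropyl on an amide-type nitrogen. Two measured steps changed this same group: an 8.6-fold lower number from compound 1 to compound 3 (0.93 log units; beyond the scatter) came with cyclopropyl in place of 4-cyclopropylphenyl, and a 9.3-fold lower number from compound 2 to compound 3 (0.97 log units; beyond the scatter) came with cyclopropyl in place of 3-methoxyphenyl. Neither step tests a cyclopentyl, so they frame the new step without fixing it. Cyclopentyl keeps a non-aromatic ring of carbon only, as cyclopropyl does, but it adds carbon, so a rise is expected that recovers part of those gaps, not all of them. The expected change in this assay is a 2.9-fold higher number from compound 3 to compound 4 (0.46 log units; beyond the scatter) as an estimate. For compound 4 the estimated clearance is 20 mL/min/kg with a range from 9 mL/min/kg to 45 mL/min/kg expected around it.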

Compound 4, clearance: 61 mL/min/kg
The estimate for compound 4 lay 3.1-fold (0.48 log units) below the measured number; measured number outside the range, above it.
By their numbers in this assay, from the lowest: compound 3; then compounds 1, 4 and 2 (each within the scatter of the next).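

In this assay the low number of compound 3 does not carry over to every non-aromatic ring of carbon on this amide-type nitrogen: with cyclopentyl in place of cyclopropyl there is an 8.7-fold higher number from compound 3 to compound 4 (0.94 log units; beyond the scatter) and the two rings differ only in size. The other two steps, a 1.1-fold lower number from compound 2 to compound 4 (0.03 log units; within the scatter) and a 1.0-fold higher number from compound 1 to compound 4 (0.01 log units; within the scatter), show that cyclopentyl cannot be told apart from the 3-methoxyphenyl or 4-cyclopropylphenyl groups here, so among these four compounds having no aromatic ring at this position does not ensure slow removal, and compound 3 alone stands apart. Nothing available gives a reason for this jump.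

A cyclobutyl ring on the same nitrogen would show whether the number climbs in stages from cyclopropyl to cyclopentyl or rises all at once. Also open, from the compounds shown here alone, is whether an open chain such as isopropyl, or a cyclopentyl ring carrying a hydroxyl group or an amine, would bring the number back towards that of compound 3.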